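Compound 2 gives way to a 2-hydroxyethoxy ester

The source may report more compounds than this note shows. Statements on the series, on what has been measured and on what is new or still open speak of the compounds shown alone.

Compound 1 `CCn1c(C(=O)N[C@H](C(=O)O)C(C)C)ccc1C(CC)(CC)c1ccc(C#CC(O)(CC)CC)c(C)c1` gives 5000 nM
Compound 2 `CCn1cc(C(CC)(CC)c2ccc(C#CC(O)(CC)CC)c(C)c2)cc1C(=O)NCC(=O)OC` gives 17500 nM

In a functional assay on PC-3 cells (Homo sapiens) for antiproliferative activity, read by MTT assay, with a stated time of 72 h (a lower number here means a stronger inhibitor, a higher number a weaker inhibitor), compound 2 holds the higher of the two numbers, and its gap to compound 1 lies beyond the scatter. Compound 3 `CCn1cc(C(CC)(CC)c2ccc(C#CC(O)(CC)CC)c(C)c2)cc1C(=O)OCCO` carries 2-hydroxyethoxy in place of ((methoxycarbonyl)methyl)amino on a carbonyl carbon. Among the measured compounds shown here, no measured step covers this change, so no shift beyond the scatter is expected in this assay. The estimated step is small (a 1.5-fold lower number from compound 2 to compound 3 (0.16 log units; within the scatter)). The estimate for compound 3 is 12000 nM, with an expected range from 4000 nM to 30000 nM (both ends estimated).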

Compound 3, half-maximal inhibitory concentration: 11400 nM
Beside the measured number, compound 3's estimate is 1.1-fold (0.02 log units) above it; the measured number falls inside the stated range.
By their numbers in this assay, from the lowest: compound 1; then compounds 3 and 2 (each within the scatter of the next).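

In this assay, putting 2-hydroxyethoxy in place of ((methoxycarbonyl)methyl)amino on this carbonyl carbon gives a 1.5-fold lower number from compound 2 to compound 3 (0.19 log units; within the scatter). Among the compounds shown here, this is the first one-place comparison at this position, and it shows that the two groups cannot be told apart here, even though the entering group is the smaller of the two. No evidence is available to explain this result.

Still open, from the compounds shown here alone, is whether a carboxylic acid, a simple amine or a longer hydroxyalkyl chain on this carbonyl carbon would move the number beyond the scatter.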